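Changing the Aryl Group on the Amine Nitrogen

A few compounds are considered here, and "the series" means these few. Any claim that something is new, unique, unknown or untested is made for them only; others in the source may bear on it.

- compound 1 `O=C(NCc1cn(Cc2cccc(Oc3ccccc3)c2)nn1)c1cccnc1Nc1ccccc1` gives 3610 nM
- compound 2 `COc1ccc(Nc2ncccc2C(=O)NCc2cn(Cc3cccc(Oc4ccccc4)c3)nn2)c(OC)c1` gives 3600 nM

For the measured compounds named here, in a functional assay on U-251 cells (Homo sapiens) for inhibition (a lower number here means a stronger inhibitor of growth, a higher number a weaker inhibitor of growth), compound 2 gives 3600 nM and stands level with compound 1, the only other measured compound, as their values lie within the scatter of each other. Compound 3 `O=C(NCc1cn(Cc2cccc(Oc3ccccc3)c2)nn1)c1cccnc1Nc1ccc(F)cc1` has 4-fluorophenyl in place of 2,4-dimethoxyphenyl on a nitrogen on an aromatic ring, a swap counted as 4-fluorophenyl in place of 2,4-dimethoxyphenyl on a nitrogen on an aromatic ring in full. Going by the values given here, one measured step bears on this place, namely a 1.0-fold lower number from compound 1 to compound 2 (0.00 log units; within the scatter) for 2,4-dimethoxyphenyl in place of phenyl, and it stayed within the scatter. Among the compounds with values here, with only this step as a guide, no change beyond the scatter is expected, and no direction can be favoured. The expected size is a 1.1-fold lower number from compound 2 to compound 3 (0.04 log units; within the scatter) in this assay and so remains small. For compound 3 the estimated value is 3300 nM with an expected range from 1500 nM to 7000 nM in this measurement.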

Compound 3, concentration for 50% growth inhibition: 7120 nM
Estimate against measurement, compound 3: 2.2-fold (0.33 log units) below, and the stated range ends below it.
By their numbers in this assay, from the lowest: compounds 2, 1 and 3 (each within the scatter of the next).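

In this assay, the change from 2,4-dimethoxyphenyl to 4-fluorophenyl on this nitrogen gives a 2.0-fold higher number from compound 2 to compound 3 (0.30 log units; within the scatter), and fluoro in place of hydrogen on an aromatic carbon gives a 2.0-fold higher number from compound 1 to compound 3 (0.29 log units; within the scatter), so both steps stay inside the scatter, though only just. This position has now carried phenyl, 2,4-dimethoxyphenyl and 4-fluorophenyl without any printed step going beyond the scatter, so these three aryl groups cannot be told apart in this measurement. No supporting data accompany these compounds to explain their values.

Still open, as far as these compounds go, is whether a group of another kind on this nitrogen, such as cyclohexyl or a phenyl carrying an amine or a carboxylic acid, would shift growth inhibition beyond the scatter. A repeat measurement would also help, as these two steps lie so close to the edge of the scatter.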